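From 3-chlorophenoxy to (3-chlorophenyl)amino on a shared core

This account rests on a few compounds, and the source may have more. Where it says the series, first, only, none or still open, it means among the compounds named here.

Compound 1 `COc1ccc(-c2nc(C(F)(F)S(=O)(=O)c3cccc(Cl)c3)nc3ccsc23)cn1`: > 50000 nM
Compound 2 `COc1ccc(-c2nc(COc3cccc(Cl)c3)nc3ccsc23)cn1`: > 50000 nM
Compound 3 `COc1ccc(-c2nc(CSc3ccc(C(F)(F)F)cn3)nc3ccsc23)cn1`: > 50000 nM

In an ADME assay on cells (Homo sapiens) for cytotoxicity, read by resazurin assay, with a stated time of 5 days (on this read-out higher numbers stand for lower toxicity in this test and lower numbers for higher toxicity in this test), compound 2 gives > 50000 nM as a limit of the assay, not a number. It shares that standing with the other two compounds (the limit of > 50000 nM in this assay, at which 3 of the 3 values shown sit).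

Compound 4 `COc1ccc(-c2nc(CNc3cccc(Cl)c3)nc3ccsc23)cn1` has (3-chlorophenyl)amino in place of 3-chlorophenoxy on a saturated chain carbon bound to an aromatic carbon.

For the measured compounds named here, no measured pair shows the size of a single change. In this assay no step beyond the scatter is therefore expected, or at most a small one toward lower numbers. The expected size is an at least 1.1-fold lower number from compound 2 to compound 4 (0.04 log units; that floor lies within the scatter) in this estimate. The estimate for compound 4 is 45000 nM (expected range 18000 nM to 60000 nM).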

Compound 4, half-maximal cytotoxic concentration: > 50000 nM
Compound 4 gave a limit, no number; the forecaster's own chance of this, stated with the estimate: 70%; middle value at least 1.1-fold (0.04 log units) away from the limit.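

In this assay compound 4 gives > 50000 nM, a limit of the assay and not a number. Compound 2 also stands at a limit, so no step can be read between compound 2 and compound 4. The compounds shown leave open whether swapping 3-chlorophenoxy for (3-chlorophenyl)amino changes the half-maximal cytotoxic concentration at all, with every value at one shared ceiling: the limit of > 50000 nM in this assay, at which 4 of the 4 values shown sit.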